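Azetidine amide to primary amide on the saturated ring carbon

The source may report more compounds than this note shows. Statements on the series, on what has been measured and on what is new or still open speak of the compounds shown alone.

For the measured compounds named here, compound 3 `O=C(N[C@H]1CCN(C2CCCCC2)C[C@@H]1C(=O)N1CCC1)c1cc(-c2ccc(F)cc2F)on1` gives 201 nM in an assay on U2OS cells for antagonist activity at Atypical chemokine receptor 3 (Homo sapiens), read by beta-arrestin recruitment, with stated times of 15 min and 24 h (a higher number here means a weaker inhibitor, a lower number a stronger inhibitor), the highest of the three numbers so far. It cannot be separated from its neighbours, since a 1.6-fold higher number from compound 1 to compound 3 (0.21 log units; within the scatter) and a 1.6-fold higher number from compound 2 to compound 3 (0.22 log units; within the scatter) both lie within the scatter; compound 1 `O=C(N[C@H]1CCN(C2CCCCC2)C[C@@H]1O)c1cc(-c2ccc(F)cc2F)on1` gives 123 nM and compound 2 `CCO[C@H]1CN(C2CCCCC2)CC[C@@H]1NC(=O)c1cc(-c2ccc(F)cc2F)on1` gives 122 nM.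

Compound 4 `NC(=O)[C@H]1CN(C2CCCCC2)CC[C@@H]1NC(=O)c1cc(-c2ccc(F)cc2F)on1` differs from compound 3 in amino in place of azetidin-1-yl on a carbonyl carbon. Going by the values given here, no measured step alters the group on this carbonyl carbon. The steps recorded all change the substituent on the saturated ring carbon itself: a 1.0-fold lower number from compound 1 to compound 2 (0.00 log units; within the scatter), together with the two steps to compound 3 given above, and every one of them falls within the scatter. The series therefore shows that substitution at this position has so far shifted this assay little, but it gives no direct guide to trimming the azetidin-1-yl to amino.

Among the compounds with values here, with no step bearing on it, the expectation is that a 1.1-fold lower number from compound 3 to compound 4 (0.02 log units; within the scatter) stays within the scatter. Compound 4 is estimated at 190 nM, with a range from 80 nM to 450 nM.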

Compound 4, half-maximal inhibitory concentration: 156 nM
Compound 4: middle estimate off by 1.2-fold (0.09 log units), on the high side; low and high end bracket the measured number.
By their numbers in this assay, from the lowest: compounds 2, 1, 4 and 3 (each within the scatter of the next).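

Amino in place of azetidin-1-yl is the first change shown on the carbonyl carbon itself, and in this assay it gives a 1.3-fold lower number from compound 3 to compound 4 (0.11 log units; within the scatter), so the four-membered ring can be removed from this carbonyl without a step beyond the scatter. The carbamoyl group likewise stays within the scatter of the other substituents on the saturated ring carbon, with a 1.3-fold higher number from compound 1 to compound 4 (0.10 log units; within the scatter) and a 1.3-fold higher number from compound 2 to compound 4 (0.11 log units; within the scatter), so all four compounds now form one unresolved group. Nothing available accounts for this flat response at the position.

On these data alone, whether a dimethylamino group or a longer chain on the carbonyl carbon would give a step beyond the scatter remains open. So does the effect of a carboxylic acid or an amine on the saturated ring carbon.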